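This account rests on a few compounds, and the source may have more. Where it says the series, first, only, none or still open, it means among the compounds named here.

Compound 1, `CCCc1cc(N2CCCC2)c2cc(NC(=O)/C=C/c3ccc(C(F)(F)F)cc3)ccc2n1`, in an assay on isolated protein for displacement of a labelled ligand from melanin-concentrating hormone receptor 1 (Homo sapiens) (a higher number here means a weaker inhibitor, a lower number a stronger inhibitor), compound 1 gives 17 nM.
Compound 2, `CCCc1cc(N2CCC2)c2cc(NC(=O)/C=C/c3ccc(C(F)(F)F)cc3)ccc2n1`, in this assay compound 2 gives 2.8 nM.

Among the compounds with values here, compound 2 has the lowest of the two numbers so far; its nearest neighbour is compound 1, and the two differ only in the ring attached to the shared core. That single step, a 6.1-fold lower number from compound 1 to compound 2 (0.78 log units; beyond the scatter), replaced pyrrolidin-1-yl with the smaller azetidin-1-yl and made the inhibitor markedly stronger.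

Compound 3, `CCCc1cc(N2CCCCC2)c2cc(NC(=O)/C=C/c3ccc(C(F)(F)F)cc3)ccc2n1`, has not yet been measured. It differs from compound 2 by piperidin-1-yl in place of azetidin-1-yl on an aromatic carbon. Within the data shown here, this goes the other way from the one measured step: the ring grows rather than shrinks. Among the measured compounds shown here, the only evidence is the step from compound 1 to compound 2, where a smaller ring gave a lower number; a larger ring is therefore expected to give a higher number, and the step is expected to be clearly beyond the scatter, with compound 3 probably ending up weaker than compound 1 as well. The expected step is a 14-fold higher number from compound 2 to compound 3 (1.15 log units; beyond the scatter). Compound 3 is thus estimated at 40 nM, with a range from 10 nM to 150 nM.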

Compound 3, half-maximal inhibitory concentration: > 4000 nM
Compound 3: a limit, no number; the forecaster's own chance of this, stated with the estimate: 2%; at least 100-fold (2.00 log units) between middle value and limit.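

Compound 3 is recorded only as a limit of the assay and not as a number: the limit of > 4000 nM in this assay, at which 1 of the 3 values shown sits.

Placing piperidin-1-yl on this aromatic carbon, opposite the ring nitrogen, gives an at least 1400-fold higher number from compound 2 to compound 3 (3.15 log units; beyond the scatter) and an at least 230-fold higher number from compound 1 to compound 3 (2.37 log units; beyond the scatter), and both steps are much larger than a 6.1-fold lower number from compound 1 to compound 2 (0.78 log units; beyond the scatter). Across these three compounds the number rises each time the ring grows, but the response is far from even: going from the four-membered to the five-membered ring costs a modest amount, whereas the six-membered ring loses nearly all measurable inhibition, so this position tolerates ring growth only up to a sharp edge.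

On these data alone, how far the true value of compound 3 lies past its limit remains unknown, so the two new steps give only minimum sizes. As far as these compounds go, it also remains open whether ring size alone sets this edge, a question that a morpholin-4-yl ring, a piperazin-1-yl ring or an open-chain dimethylamino group on the same aromatic carbon would help to answer.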